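Anilinyl piperazine variant: expected tolerance in MT4 cells

The compounds below may be only part of what the source reports. "The series", "measured", "known", "first", "only" and "open" are said of these compounds alone.

Measured so far:
- compound 1 `COc1cc(Cc2cnc(/N=C3\C(=O)N(CN4CCCCC4C)c4ccc(Cl)cc43)nc2N)cc(OC)c1OC`: 97.3 ug/mL
- compound 2 `COc1cc(Cc2cnc(/N=C3\C(=O)N(CN4CCN(Cc5ccccc5)CC4)c4ccc(Cl)cc43)nc2N)cc(OC)c1OC`: 36.1 ug/mL
- compound 3 `COc1cc(Cc2cnc(/N=C3\C(=O)N(CN4CCN(C)CC4)c4ccc(Cl)cc43)nc2N)cc(OC)c1OC`: 80.7 ug/mL

In an ADME assay on MT4 cells (Homo sapiens) for cytotoxicity, read by MTT assay, with a stated time of 5 days (a higher number here means that more compound is tolerated, a lower number that less compound is tolerated), compound 3 stands second highest of the three numbers; it sits within the scatter of compound 1, as shown by a 1.2-fold lower number from compound 1 to compound 3 (0.08 log units; within the scatter), and apart from compound 2, since a 2.2-fold higher number from compound 2 to compound 3 (0.35 log units; beyond the scatter) is a modest step beyond the scatter.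

Compound 4 `COc1cc(Cc2cnc(/N=C3\C(=O)N(CN4CCN(c5ccc(Cl)cc5)CC4)c4ccc(Cl)cc43)nc2N)cc(OC)c1OC` differs from compound 3 by 4-chlorophenyl in place of methyl on an amine nitrogen in a ring. For the measured compounds named here, only one measured step touches this kind of change: a 2.2-fold higher number from compound 2 to compound 3 (0.35 log units; beyond the scatter), where a ring bearing a phenyl group on the amine nitrogen gave the lower number, and its removal gave the higher one. Going by the values given here, compound 4 again places an aromatic ring on that nitrogen, so a modest lowering of the tolerated concentration in this assay, about the size of that step, is expected, while no step of any other kind bears on it.

Compound 4 is therefore estimated at 35 ug/mL, between 15 ug/mL and 80 ug/mL, which means an expected step of a 2.3-fold lower number from compound 3 to compound 4 (0.36 log units; beyond the scatter).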

Compound 4, half-maximal cytotoxic concentration: 38.6 ug/mL
The estimate for compound 4 lay 1.1-fold (0.04 log units) below the measured number; the range from low to high includes it.
By their numbers in this assay, from the lowest: compounds 2 and 4 (each within the scatter of the next); then compounds 3 and 1 (each within the scatter of the next).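

In this assay, 4-chlorophenyl in place of methyl on the ring amine nitrogen gives a 2.1-fold lower number from compound 3 to compound 4 (0.32 log units; beyond the scatter) and so is a modest step, which means that the lower number seen with benzyl on this nitrogen now also appears with a second aromatic group. The two large groups cannot be separated here, since 4-chlorophenyl in place of benzyl gives a 1.1-fold higher number from compound 2 to compound 4 (0.03 log units; within the scatter) and stays within the scatter. Nothing measured here explains why either group stands apart from methyl.

From the compounds shown here alone, it remains open whether a non-aromatic group on this nitrogen, such as cyclohexyl or a longer chain, would give a number like compound 3 or one like compound 4. Going by these compounds, it is also open whether plain phenyl, without the chlorine, would fall with compound 4.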